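Anilino in place of piperidin-1-yl on the carbonyl

This account rests on a few compounds, and the source may have more. Where it says the series, first, only, none or still open, it means among the compounds named here.

Three amides sharing one core have been tested in a functional assay on MDA-MB-231 cells (Homo sapiens) for antiproliferative activity, read by sulforhodamine B assay, with a stated time of 48 h; on this read-out lower numbers stand for stronger inhibition and higher numbers for weaker inhibition. Compound 1 `CCN(CC)C(=O)c1cccc(C2SCC(=O)N2c2ccccc2OC)c1` gives > 50000 nM, which is a limit and not a number. Compound 2 `C=CCN(CC=C)C(=O)c1cccc(C2SCC(=O)N2c2ccccc2OC)c1` gives > 50000 nM, again a limit. Compound 3 `COc1ccccc1N1C(=O)CSC1c1cccc(C(=O)N2CCCCC2)c1` gives > 50000 nM, also a limit. Compound 3 therefore has no number of its own and stands with the other two, as the limit of > 50000 nM in this assay, at which 3 of the 3 values shown sit, shows.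

Compound 4 `COc1ccccc1N1C(=O)CSC1c1cccc(C(=O)Nc2ccccc2)c1` carries anilino in place of piperidin-1-yl on a carbonyl carbon. The measured steps at this same place are a step that the two limits leave unreadable from compound 1 to compound 2, a step that the two limits leave unreadable from compound 1 to compound 3 and a step that the two limits leave unreadable from compound 2 to compound 3. None of them has a readable size, and none brings in anilino, so they offer no size to carry over. Another result at the limit is the likeliest outcome, and any gain in inhibition would be a modest one. The expected change is an at least 1.1-fold lower number from compound 3 to compound 4 (0.04 log units; that floor lies within the scatter). For compound 4 the estimate is 45000 nM, with an expected range of 10000 nM to 100000 nM.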

Compound 4, half-maximal inhibitory concentration: > 25000 nM
Compound 4: no number, only a limit; the forecaster's own chance of this, stated with the estimate: 65%; the middle value does not contradict the limit.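

Compound 4 also gives only a limit, so its steps to compound 1, compound 2 and compound 3 cannot be read, as each compares two limits. The compounds shown leave open how strongly any of these four amides acts in this assay, and whether the group on the carbonyl changes that at all.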